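The source may report more compounds than this note shows. Statements on the series, on what has been measured and on what is new or still open speak of the compounds shown alone.

Three compounds have been measured in a functional assay on MDA-MB-231 cells (Homo sapiens) for inhibition, read by sulforhodamine B assay, tested at 10 uM; on this read-out higher numbers stand for more inhibition at the one concentration tested (going by the name of the read-out) and lower numbers for less inhibition:
Compound 1, `CN1CCN(c2ccc(C3=NN(S(C)(=O)=O)C(c4ccc(N(C)C)cc4)C3)cc2)CC1`, gives 0.6%.
Compound 2, `CN1CCN(c2ccc(C3=NN(S(=O)(=O)C4CC4)C(c4ccc(N(C)C)cc4)C3)cc2)CC1`, gives 3.7%.
Compound 3, `CN1CCN(c2ccc(C3=NN(S(=O)(=O)c4ccc(Br)cc4)C(c4ccc(N(C)C)cc4)C3)cc2)CC1`, gives 23.7%.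

Compound 3 stands highest of the three, with a number 23.1 percentage points higher from compound 1 to compound 3 (beyond the scatter) and a number 20 percentage points higher from compound 2 to compound 3 (beyond the scatter), whereas a number 3.1 percentage points higher from compound 1 to compound 2 (within the scatter). Compound 4, `CN1CCN(c2ccc(C3=NN(S(=O)(=O)c4ccc(C(F)(F)F)cc4)C(c4ccc(N(C)C)cc4)C3)cc2)CC1`, differs from compound 3 in one place: trifluoromethyl in place of bromo on an aromatic carbon. Within the data shown here, every measured step exchanged the whole group on the sulfonyl sulfur, and only the two leading to compound 3 were beyond the scatter; none of them swapped one substituent of the 4-bromophenyl ring for another, so no measured step bears directly on this change. The expectation is therefore a step of no size beyond the scatter, estimated as a number 1.3 percentage points higher from compound 3 to compound 4 (within the scatter) in this assay. Compound 4 is thus expected to give about 25%, likely between 8% and 45%.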

Compound 4, a percentage reported as inhibition, at one concentration (the size of the read-out at that concentration, not a potency): 12.1%
The estimate for compound 4 lay 12.9 percentage points above the measured number, within the range that was stated.
By their numbers in this assay, from the lowest: compounds 1, 2 and 4 (each within the scatter of the next, the first and the last beyond it); then compound 3.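

In this assay, replacing bromo with trifluoromethyl gives a number 11.6 percentage points lower from compound 3 to compound 4 (beyond the scatter) and shows that the substituent on this ring matters, not only the presence of an aromatic ring on the sulfonyl sulfur. The 4-(trifluoromethyl)phenyl group gives a number 11.5 percentage points higher from compound 1 to compound 4 (beyond the scatter) but only a number 8.4 percentage points higher from compound 2 to compound 4 (within the scatter) so its gain is clear over methyl and not over cyclopropyl.

Going by these compounds, how a methoxy group, a nitrile or an amine in the same place would compare remains open. No measurement here explains the gap between bromo and trifluoromethyl.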